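This account rests on a few compounds, and the source may have more. Where it says the series, first, only, none or still open, it means among the compounds named here.

Among the measured compounds shown here, compound 1 `CC/N=C(\S)CCn1nc(-c2ccccc2)ccc1=O` is the one compound in this set with a number in a functional assay on the whole organism (stomach) with Rattus norvegicus as the target; on this read-out higher numbers stand for an effect only at larger amounts of compound and lower numbers for an effect already at smaller amounts: compound 1 gives 100 mg/kg. Compound 2 `Cc1ccc(=O)n(CCCCCCC(=N)S)n1` yields no number in this assay, only a limit, > 100 mg/kg, which is the limit of > 100 mg/kg in this assay, at which 1 of the 2 values shown sits. Compound 3 `N=C(S)CCn1nc(-c2ccccc2)ccc1=O` differs from compound 1 by a group of 3 heavy atoms (1 carbon, 1 nitrogen, 1 sulfur; no ring) in place of a group of 5 heavy atoms (3 carbon, 1 nitrogen, 1 sulfur; no ring), on a saturated chain carbon, two bonds along the chain from an aromatic nitrogen. No measured pair in the set shares this change, so nothing shown sizes it. The step expected in this assay is no change at the digits printed from compound 1 to compound 3 (within the scatter), that is, none beyond the scatter. Compound 3 is therefore estimated at 100 mg/kg, with a range from 40 mg/kg to 250 mg/kg.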

Compound 3, dose for half-maximal effect: 87.3 mg/kg
Compound 3: the middle estimate sits 1.1-fold (0.06 log units) above what was measured; low and high end bracket the measured number.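

In this assay, among the compounds shown here, this change now has a size for the first time: swapping the group of 5 heavy atoms for the group of 3 heavy atoms on this saturated chain carbon gives a 1.1-fold lower number from compound 1 to compound 3 (0.06 log units; within the scatter). At this position, the two groups are therefore not told apart by this read-out. Nothing shown gives a cause for this.

A single pair cannot show whether the same holds on other cores. On these data alone, how a carboxylic acid, an amine or a longer chain would read at this position also remains open.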